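This account rests on a few compounds, and the source may have more. Where it says the series, first, only, none or still open, it means among the compounds named here.

Measured so far:

Compound 1 `Oc1cccc(-c2cc(-c3ccccn3)cc(-c3ccccc3O)n2)c1`: 35.4%
Compound 2 `Oc1ccc(-c2cc(-c3ccccn3)cc(-c3ccccc3O)n2)cc1`: 0.2%
Compound 3 `Oc1cccc(-c2cc(-c3cccnc3)cc(-c3cccc(O)c3)n2)c1`: 2.1%

The three compounds were tested in an assay on isolated protein for inhibition of DNA topoisomerase 1 (Homo sapiens), with a stated time of 30 min, tested at 100 uM; a lower number here means a weaker effect, a higher number a stronger effect of the compound at the concentration tested. Compound 1 gives 35.4%, whereas compound 2 gives 0.2%. The two differ in one place, (4-hydroxyphenyl in place of 3-hydroxyphenyl on an aromatic carbon), and this change produced a step of a number 35.2 percentage points lower from compound 1 to compound 2 (beyond the scatter). Compound 3 gives 2.1% in this assay ; the difference between its core and the core of compound 1 is not broken down here.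

Compound 4 `Oc1ccc(-c2cc(-c3cccnc3)cc(-c3cccc(O)c3)n2)cc1` has not yet been measured. It differs from compound 3 in one place, (4-hydroxyphenyl in place of 3-hydroxyphenyl on an aromatic carbon). For the measured compounds named here, this is the same kind of change as the one from compound 1 to compound 2, though the surroundings are not the same: in compound 1 the altered position is meta to a 2-hydroxyphenyl group and meta to a pyridin-2-yl group, whereas in compound 3 it is meta to a 3-hydroxyphenyl group and meta to a pyridin-3-yl group.

Going by the values given here, the one earlier instance of this change lowered the read-out sharply. Compound 3, however, already stands close to the bottom of the scale with 2.1%, so a downward step of the same size is not possible. The step from compound 3 to compound 4 is therefore expected to be small, a number 1.1 percentage points lower from compound 3 to compound 4 (within the scatter), because compound 3 gives 2.1% and little room remains below it. Compound 4 is expected to give about 1% in this assay , estimated to lie between -6% and 9%.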

Compound 4, a percentage reported as inhibition, at one concentration (the size of the read-out at that concentration, not a potency): 5.9%
Estimate against measurement, compound 4: 4.9 percentage points below; low and high end bracket the measured number.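

In this assay, the exchange of 3-hydroxyphenyl for 4-hydroxyphenyl did not carry over from one core to the other, and the two steps differ: the same change on two cores in this assay, a number 35.2 percentage points lower (beyond the scatter) from compound 1 to compound 2 and a number 3.8 percentage points higher (within the scatter) from compound 3 to compound 4, 39 percentage points apart, beyond the scatter of two such steps

On the core of compound 3 the exchange gave a number 3.8 percentage points higher from compound 3 to compound 4 (within the scatter), so there the two compounds cannot be told apart, while on the core of compound 1 it took away nearly all of the read-out. For the compounds shown here, this does not show what in the core decides the outcome: the two cores differ in more than one group, only two pairs are available, and compound 3 already sits low at 2.1%, so that core had little room to show a drop of the earlier size.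

What the compounds shown leave open is whether the exchange would again remove the read-out on a further core with a clear starting value, and which of the differing groups on the two cores, the 2-hydroxyphenyl or the pyridin-2-yl, goes with the sensitivity seen for compound 1. Also open, from the compounds shown here alone, is how the read-out would respond if the hydroxyl on these phenyl groups gave way to an amine, a methoxy group or a carboxylic acid.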